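The source may report more compounds than this note shows. Statements on the series, on what has been measured and on what is new or still open speak of the compounds shown alone.

Among the measured compounds shown here, in a functional assay on HepG2 cells (Homo sapiens) for antiproliferative activity, read by MTT assay, with a stated time of 24 h (on this read-out lower numbers stand for stronger inhibition and higher numbers for weaker inhibition), compound 2 `Brc1ccccc1CSc1nnc(-c2ccc3c(c2)OCCO3)n1-c1ccccc1` gives 4730 nM, the lower of the two numbers so far, while compound 1 `O=[N+]([O-])c1ccc(CSc2nnc(-c3ccc4c(c3)OCCO4)n2-c2ccccc2)cc1` gives 13800 nM. Compound 3 `Brc1ccc(CSc2nnc(-c3ccc4c(c3)OCCO4)n2-c2ccccc2)cc1` has not yet been measured. It carries 4-bromophenyl in place of 2-bromophenyl on a saturated chain carbon bound to a sulfur. For the measured compounds named here, the only measured step bearing on this is a 2.9-fold lower number from compound 1 to compound 2 (0.47 log units; beyond the scatter), a modest one that also changes the group itself, so only a small rise is expected. The estimated step is a 1.4-fold higher number from compound 2 to compound 3 (0.14 log units; within the scatter). Compound 3 is expected to give about 6500 nM, with an estimated range of 2500 nM to 16000 nM.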

Compound 3, half-maximal inhibitory concentration: 7940 nM
Compound 3: the middle estimate sits 1.2-fold (0.09 log units) below what was measured; low and high end bracket the measured number.
By their numbers in this assay, from the lowest: compounds 2, 3 and 1 (each within the scatter of the next, the first and the last beyond it).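

Swapping 2-bromophenyl for 4-bromophenyl on the saturated chain carbon bound to sulfur (a 1.7-fold higher number from compound 2 to compound 3 (0.22 log units; within the scatter)) leaves the two bromine placements indistinguishable on this read-out. Bromo in place of nitro on an aromatic carbon (a 1.7-fold lower number from compound 1 to compound 3 (0.24 log units; within the scatter)) also stays within the scatter. Each change alone is therefore too small to read, although the combined difference (a 2.9-fold lower number from compound 1 to compound 2 (0.47 log units; beyond the scatter)) is beyond the scatter. Nothing measured here offers a reason for these numbers. Still open, as far as these compounds go, is how an amine or a carboxylic acid on this ring, or a longer chain before the ring, would read.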